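The source may hold more compounds than are shown below. What is called first, only, known or untested is meant among the compounds shown, and "the series" means these compounds.

Three compounds carrying the shared core of compound 1 `C1=C(CCN2CCN(c3cccc4c3OCCO4)CC2)c2ccccc2CCC1` have been run in a functional assay on the whole organism for antagonist activity, with Rattus norvegicus as the target; on this read-out lower numbers stand for an effect already at smaller amounts and higher numbers for an effect only at larger amounts of compound. Compound 1 gives 2.5 mg/kg. Compound 2 `c1ccc2c(c1)CC(CCCN1CCN(c3cccc4c3OCCO4)CC1)C2` gives 0.63 mg/kg, the lowest of the three numbers, beyond the scatter from both neighbours. Compound 3 `c1ccc2c(c1)CCCCC2CCN1CCN(c2cccc3c2OCCO3)CC1` gives 5 mg/kg, the highest of the set.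

Compound 4 `c1ccc2c(c1)CC2CCCN1CCN(c2cccc3c2OCCO3)CC1` has not been measured. It differs from compound 2 in one place: a group of 8 heavy atoms (8 carbon; one four-membered non-aromatic ring of carbon only, one six-membered aromatic ring of carbon only) in place of a group of 9 heavy atoms (9 carbon; one five-membered non-aromatic ring of carbon only, one six-membered aromatic ring of carbon only), on a saturated chain carbon, three bonds along the chain from an amine nitrogen in a ring. Going by the values given here, no pair of measured compounds isolates this change, so the expected step in this assay rests on the change alone. A modest shift toward a higher number, possibly within the scatter, is expected, so that the estimated step of a 1.9-fold higher number from compound 2 to compound 4 (0.28 log units; within the scatter) stays small. Compound 4 is therefore estimated at 1.2 mg/kg, with a range from 0.4 mg/kg to 4 mg/kg.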

Compound 4, minimum effective dose: 0.16 mg/kg
For compound 4 the middle estimate is 7.5-fold (0.88 log units) above the measured one, outside the stated range (below it).
By their numbers in this assay, from the lowest: compound 4; then compound 2; then compounds 1 and 3 (each within the scatter of the next).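

In this assay, the ring with the four-membered non-aromatic part, in place of 2,3-dihydro-1H-inden-2-yl, gives a 3.9-fold lower number from compound 2 to compound 4 (0.60 log units; beyond the scatter). Going by these compounds alone, this is the first change that can be read in one place, and it shows that on this saturated chain carbon the group with fewer heavy atoms is not merely tolerated, since the number falls beyond the scatter. Nothing measured bears on the reason for this step.

On these data alone, it remains open whether a methyl group or a hydroxyl group on the four-membered ring would preserve this result. A longer chain carrying the same group is equally unresolved.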